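The source may report more compounds than this note shows. Statements on the series, on what has been measured and on what is new or still open speak of the compounds shown alone.

Working notes on the series. For the measured compounds named here, in a functional assay on HepG2 cells (Homo sapiens) for inhibition, read by MTT assay, with a stated time of 72 h (a higher number here means a weaker inhibitor, a lower number a stronger inhibitor), compound 3 `CCCCCCc1cn(Cc2cc(=O)oc3cc(O)ccc23)nn1` gives 61600 nM, the only number in the set so far. Compound 1 `O=c1cc(Cn2cc(CCO)nn2)c2ccc(O)cc2o1` gives > 100000 nM in this assay, which is a limit and not a number. Compound 2 `CC(O)c1cn(Cc2cc(=O)oc3cc(O)ccc23)nn1` gives > 100000 nM in this assay, again a limit. Because of the limit of > 100000 nM in this assay, at which 2 of the 3 values shown sit, the steps into compound 3 are read only as floors: an at least 1.6-fold lower number from compound 1 to compound 3 (0.21 log units; that floor lies within the scatter) and an at least 1.6-fold lower number from compound 2 to compound 3 (0.21 log units; that floor lies within the scatter), while a step that the two limits leave unreadable from compound 1 to compound 2. Compound 4 `O=c1cc(Cn2cc(CCc3ccccc3)nn2)c2ccc(O)cc2o1` is not yet measured. The change from compound 3: phenyl in place of butyl on a saturated chain carbon, two bonds along the chain from an aromatic carbon. Going by the values given here, the only measured steps that bear on it are the two into compound 3, each a floor that lies within the scatter, and neither exchanges a chain for a ring. No step beyond the scatter is therefore expected in this assay; the direction, if any, would follow the two floors toward a lower number. Compound 4 is expected to give 40000 nM in this assay, with a range from 15000 nM to 100000 nM. The estimated step is a 1.5-fold lower number from compound 3 to compound 4 (0.19 log units; within the scatter).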

Compound 4, half-maximal inhibitory concentration: 50500 nM
Compound 4: the middle estimate sits 1.3-fold (0.10 log units) below what was measured, and the stated range covers the measured number.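

For the compounds shown here, on the saturated chain carbon, two bonds along the chain from an aromatic carbon, the exchange of butyl for phenyl gives a 1.2-fold lower number from compound 3 to compound 4 (0.09 log units; within the scatter) in this assay, so at this place a six-membered aromatic ring of carbon only and an open chain read alike, which no earlier step could show. Against the hydroxy-bearing chains, the series now has an at least 1.9-fold lower number from compound 2 to compound 4 (0.29 log units; that floor lies within the scatter) and an at least 1.9-fold lower number from compound 1 to compound 4 (0.29 log units; that floor lies within the scatter), and with compound 3 these leave no step beyond the scatter anywhere in the set. Both steps stay floors and cannot be sized: the limit of > 100000 nM in this assay, at which 2 of the 4 values shown sit.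

As far as these compounds go, whether an amine or a carboxylic acid on this chain, or a chain longer than hexyl, would give a step beyond the scatter remains open. Any difference between 1-hydroxyethyl and 2-hydroxyethyl also remains unreadable.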